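This account rests on a few compounds, and the source may have more. Where it says the series, first, only, none or still open, it means among the compounds named here.

Series notes. Compound 1 `COc1ccc(-c2cn3ccnc3c(-c3ccc4ncn(C5CCCCC5)c4c3)n2)cc1` and compound 2 `c1ccc2c(-c3cn4ccnc4c(-c4ccc5ncn(C6CCCCC6)c5c4)n3)cccc2c1` share one core and differ only in the group on the aromatic carbon. In a functional assay on MCF7 cells (Homo sapiens) for inhibition, read by sulforhodamine B assay, with a stated time of 48 h, tested at 10 uM (on this read-out higher numbers stand for more inhibition at the one concentration tested (going by the name of the read-out) and lower numbers for less inhibition), compound 1 gives 80.2%. In this assay compound 2 gives 13%. Going by the values given here, the step of a number 67.2 percentage points lower from compound 1 to compound 2 (beyond the scatter) is the only measured step in the set. Compound 2 stands lowest of the two numbers shown; its nearest neighbour is compound 1, higher by a margin well beyond the scatter. Compound 3 `Fc1ccc(-c2cn3ccnc3c(-c3ccc4ncn(C5CCCCC5)c4c3)n2)cc1` is not yet measured and differs from compound 2 by 4-fluorophenyl in place of naphthalen-1-yl on an aromatic carbon. The change goes back from a group of two six-membered aromatic rings of carbon only to a single six-membered aromatic ring of carbon only, as in compound 1, so the step from compound 1 to compound 2 bears on it directly, read in the opposite direction; whether fluorine matches methoxy in this position is not covered by any measured pair, which widens the range. Compound 3 is therefore expected to rise by a number 47 percentage points higher from compound 2 to compound 3 (beyond the scatter) in this assay. The estimate for compound 3 is 60%, with a range from 25% to 85%.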

Compound 3, a percentage reported as inhibition, at one concentration (the size of the read-out at that concentration, not a potency): 9.17%
The estimate for compound 3 lay 50.8 percentage points above the measured number; measured number below the stated range.
By their numbers in this assay, from the lowest: compounds 3 and 2 (each within the scatter of the next); then compound 1.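

In this assay the step of a number 3.8 percentage points lower from compound 2 to compound 3 (within the scatter) lies within the scatter, so at this position, on an aromatic carbon next to the ring nitrogen, 4-fluorophenyl and naphthalen-1-yl cannot be told apart, and going back to a single six-membered aromatic ring of carbon only does not by itself bring back the high number seen with compound 1. The large change now also appears with the ring count held constant: the step of a number 71 percentage points lower from compound 1 to compound 3 (beyond the scatter) comes from fluoro in place of methoxy alone, so among these three compounds the group on the single ring matters as much as the number of rings, and only compound 1 with its 4-methoxyphenyl stands apart. No measured information on the origin of this gap is at hand.

Still open, going by these compounds, is whether the high number is tied to methoxy itself or would also be reached with another group in its place on the ring, such as ethoxy, hydroxy or dimethylamino. The compounds shown also leave open how far this result depends on the cyclohexyl group, which is common to all three, and whether a smaller group such as methyl or a chain such as butyl there would change the picture.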